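The source may hold more compounds than are shown below. What is called first, only, known or untested is meant among the compounds shown, and "the series" means these compounds.

Among the measured compounds shown here, compound 3, `Nc1cccc(/C=C2\SC(=O)N(Cc3ccc(F)cc3)C2=O)c1`, is one of three compounds measured in a functional assay on CCRF-CEM cells (Homo sapiens) for cytotoxicity, read by cell counting, with a stated time of 3 days; on this read-out lower numbers stand for stronger inhibition and higher numbers for weaker inhibition. Its neighbour compound 2, `Nc1ccc(/C=C2\SC(=O)N(Cc3ccc(F)cc3)C2=O)cc1`, gives 111000 nM in this assay, and compound 3 itself gives 87000 nM; the two lie within the scatter of each other, as a 1.3-fold lower number from compound 2 to compound 3 (0.11 log units; within the scatter) shows. Far from both stands compound 1, `C=C(Br)C(=O)Nc1cccc(/C=C2\SC(=O)N(Cc3ccc(F)cc3)C2=O)c1`, which gives 680 nM in this assay; the gap a 130-fold higher number from compound 1 to compound 3 (2.11 log units; beyond the scatter) is the only large step among the three, and it belongs to the acylated nitrogen, not to the benzyl ring. Compound 3 thus sits at the weak end of the three numbers, close to compound 2.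

Compound 4, `Cc1ccc(CN2C(=O)S/C(=C\c3cccc(N)c3)C2=O)cc1`, differs from compound 3 by methyl in place of fluoro on an aromatic carbon. For the measured compounds named here, neither measured step touches this part of the molecule, so there is no direct precedent; the only step of comparable size, a 1.3-fold lower number from compound 2 to compound 3 (0.11 log units; within the scatter), moved an amino group on the other ring and stayed within the scatter. A change of one heavy atom with no ring and no donors or acceptors is therefore expected to give no step beyond the scatter, a 1.0-fold higher number from compound 3 to compound 4 (0.01 log units; within the scatter). Compound 4 is estimated to give 90000 nM in this assay, within a range of 30000 nM to 270000 nM.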

Compound 4, half-maximal inhibitory concentration: > 250000 nM
Compound 4: no number, only a limit; the forecaster's own chance of this, stated with the estimate: 15%; at least 2.7-fold (0.44 log units) between middle value and limit.
By their numbers in this assay, from the lowest: compound 1; then compounds 3 and 2 (each within the scatter of the next). At a limit, above all of these: compound 4.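

Compound 4 gives no number in this assay, only a limit: the limit of > 250000 nM in this assay, at which 1 of the 4 values shown sits.

Even so, the result shows something the earlier compounds could not, as neither of their steps touched the benzyl ring. On an aromatic carbon para to a large group, methyl in place of fluoro gives an at least 2.8-fold higher number from compound 3 to compound 4 (0.45 log units; beyond the scatter), so this position is not silent, even though the exchange swaps one heavy atom for one heavy atom and counts no hydrogen-bond donors or acceptors on either side. On these data alone, the step runs towards weaker inhibition, and the limit fixes only its lower bound, so its true size remains unknown.

The compounds shown leave open whether the gap reflects something fluoro contributes or something methyl costs, a question that a benzyl ring carrying plain hydrogen, chlorine or methoxy at this place would begin to answer. They also leave open whether the same exchange would carry over to the acylated compound 1, which gives 680 nM, or whether it matters only for the free amines.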